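A few compounds are considered here, and "the series" means these few. Any claim that something is new, unique, unknown or untested is made for them only; others in the source may bear on it.

In a functional assay on Huh-7 cells (Homo sapiens) for cytotoxicity, with a stated time of 48 h (on this read-out lower numbers stand for stronger inhibition and higher numbers for weaker inhibition), compound 2 `N#Cc1ccc(-c2cc(COC(Cc3cn(C4CCN(Cc5ccc([N+](=O)[O-])cc5)CC4)nn3)c3ccc(Br)cc3)on2)cc1` gives 5000 nM, the highest of the two numbers recorded so far. Its nearest neighbour is compound 1 `O=[N+]([O-])c1ccc(CN2CCC(n3cc(CC(OCc4cc(-c5ccc(F)cc5)no4)c4ccc(Br)cc4)nn3)CC2)cc1`, which gives 2000 nM and differs from compound 2 in one place, cyano in place of fluoro on an aromatic carbon; that step, a 2.5-fold higher number from compound 1 to compound 2 (0.40 log units; beyond the scatter), lies beyond the scatter. Compound 3 `O=[N+]([O-])c1ccc(CN2CCC(n3cc(CC(OCc4cc(-c5ccccc5Br)no4)c4ccc(Br)cc4)nn3)CC2)cc1` has not yet been measured. It differs from compound 2 by 2-bromophenyl in place of 4-cyanophenyl on an aromatic carbon. For the measured compounds named here, no measured step reproduces this exact change. Going by the values given here, the single step available, a 2.5-fold higher number from compound 1 to compound 2 (0.40 log units; beyond the scatter), shows that exchanging the group on that aromatic carbon of the five-membered ring moved the number by a modest amount. Compound 3 removes the cyano group again and instead carries a halogen, as compound 1 does, though a different halogen and attached differently. The expected step is therefore small and more likely toward a lower number than a higher one, a 1.7-fold lower number from compound 2 to compound 3 (0.22 log units; within the scatter). Compound 3 is estimated at 3000 nM, with a range from 1000 nM to 8000 nM.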

Compound 3, half-maximal inhibitory concentration: > 25000 nM
Compound 3: no number, only a limit; the forecaster's own chance of this, stated with the estimate: 10%; at least 8.3-fold (0.92 log units) between middle value and limit.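

In this assay compound 3 gives no number, only a limit: the limit of > 25000 nM in this assay, at which 1 of the 3 values shown sits. For the compounds shown here, until now, the one exchange on this aromatic carbon of the five-membered aromatic ring had moved the number modestly, whereas 2-bromophenyl in place of 4-cyanophenyl gives an at least 5.0-fold higher number from compound 2 to compound 3 (0.69 log units; beyond the scatter), and 2-bromophenyl in place of 4-fluorophenyl gives an at least 12-fold higher number from compound 1 to compound 3 (1.09 log units; beyond the scatter). The group on this carbon can therefore shift the read-out well beyond what the first pair showed, and carrying a halogen on the phenyl ring does not by itself keep the number close to that of compound 1.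

The compounds shown cannot separate the effect of having bromine rather than fluorine from that of where the halogen sits on the phenyl ring, since 2-bromophenyl differs from 4-fluorophenyl in both respects at once. They also leave open how a plain phenyl group without any halogen, or a phenyl ring bearing an amine, would read in this assay on this same carbon.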